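The source may report more compounds than this note shows. Statements on the series, on what has been measured and on what is new or still open speak of the compounds shown alone.

Compound 2 `COc1ccccc1N1CCN(CCCCNC(=O)c2ccc([N+](=O)[O-])cc2)CC1` and compound 1 `O=C1c2ccccc2C(=O)N1CCCCN1CCN(c2ccccc2[N+](=O)[O-])CC1` were both examined in an assay on frontal cortex for binding affinity to Adrenergic receptor alpha-1 (Rattus norvegicus), read by radioligand binding; a higher number here means a weaker inhibitor, a lower number a stronger inhibitor. In this assay compound 1 gives 25 nM, and compound 2 gives 14 nM; the two numbers lie within the scatter of each other, so neither is set apart from the other. Compound 3 `COc1ccccc1N1CCN(CCCCNC(=O)c2ccc(I)cc2)CC1` has not yet been measured. Compound 3 differs from compound 2 in one place: iodo in place of nitro on an aromatic carbon. Within the data shown here, no measured pair shows this change, so its size is unknown from the data. The step from compound 2 to compound 3 is expected to stay within the scatter, a 1.2-fold lower number from compound 2 to compound 3 (0.07 log units; within the scatter). Compound 3 is therefore estimated at 12 nM, between 4 nM and 40 nM.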

Compound 3, inhibition constant: 15 nM
Compound 3: middle estimate off by 1.3-fold (0.10 log units), on the low side; the range from low to high includes it.
By their numbers in this assay, from the lowest: compounds 2, 3 and 1 (each within the scatter of the next).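

Iodo in place of nitro on this aromatic carbon gives a 1.1-fold higher number from compound 2 to compound 3 (0.03 log units; within the scatter) in this assay. Among these compounds, this is the first measured pair at this position, and it shows that the number stays within the scatter even though the entering group has one heavy atom against three and no hydrogen-bond acceptors against two. Nothing measured here accounts for this result. From the compounds shown here alone, whether an amine or a carboxylic acid on this aromatic carbon would also stay within the scatter of compound 2 remains open.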